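Replacing 3-nitrophenyl with 2-chlorophenyl on a saturated ring carbon

This account rests on a few compounds, and the source may have more. Where it says the series, first, only, none or still open, it means among the compounds named here.

Measured compounds:
Compound 1, `COc1ccc(C2C(C#N)=C(N)N(c3cc(OC)c(OC)c(OC)c3)C3=C2C(=O)CC(C)(C)C3)cc1`: 15%
Compound 2, `COc1cc(N2C(N)=C(C#N)C(c3cccc([N+](=O)[O-])c3)C3=C2CC(C)(C)CC3=O)cc(OC)c1OC`: 30%

In a functional assay on Ehrlich cells (Mus musculus) for cytotoxicity, tested at 100 ug/mL (on this read-out lower numbers stand for a weaker effect and higher numbers for a stronger effect at the one concentration tested), compound 1 gives 15%, and compound 2 gives 30%. Among the compounds with values here, compound 2 therefore stands highest of the two numbers; the only measured step, a number 15 percentage points higher from compound 1 to compound 2 (beyond the scatter), separates it from compound 1 by more than the scatter. Compound 3, `COc1cc(N2C(N)=C(C#N)C(c3ccccc3Cl)C3=C2CC(C)(C)CC3=O)cc(OC)c1OC`, is not yet measured. Its change from compound 2 is 2-chlorophenyl in place of 3-nitrophenyl on a saturated ring carbon. Within the data shown here, the measured step bears on this same saturated ring carbon, but the group entering there is a different one, so it shows only that changing this group can move the read-out by a modest amount in either direction. The step expected in this assay is therefore small, most likely within the scatter or slightly downward, a number 5 percentage points lower from compound 2 to compound 3 (within the scatter). Compound 3 is thus estimated at 25%, with a range from 8% to 45%.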

Compound 3, a percentage reported as activity, at one concentration (the size of the read-out at that concentration, not a potency): 20%
For compound 3 the middle estimate is 5 percentage points above the measured one; the measured number falls inside the stated range.
By their numbers in this assay, from the lowest: compounds 1, 3 and 2 (each within the scatter of the next, the first and the last beyond it).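

In this assay, within the data shown here, the swap to 2-chlorophenyl on this saturated ring carbon gives a number 10 percentage points lower from compound 2 to compound 3 (within the scatter) and also a number 5 percentage points higher from compound 1 to compound 3 (within the scatter) so compound 3 cannot be told apart from either of the earlier compounds, even though those two differ from each other by more than the scatter. A phenyl ring without a nitro group can therefore still give a number within the scatter of compound 2, yet the same number is also within the scatter of compound 1, so the three compounds do not set the aryl groups in a clear order. No measurement at hand explains these numbers.

The compounds shown leave open whether the chlorine itself or its place on the ring matters, which 3-chlorophenyl or 4-chlorophenyl at this carbon would address. They also leave open how an unsubstituted phenyl or a pyridyl ring would read out here, and with a single tested concentration they say nothing about potency.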